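The source may report more compounds than this note shows. Statements on the series, on what has been measured and on what is new or still open speak of the compounds shown alone.

Measured compounds in this series:
- compound 1 `COc1ncnc2c1c(I)cn2[C@@H]1O[C@H](CO)[C@@H](O)[C@H]1O`; in a functional assay on HepG2 cells (Homo sapiens) for antiproliferative activity, read by XTT assay, with a stated time of 72 h (on this read-out lower numbers stand for stronger inhibition and higher numbers for weaker inhibition), compound 1 gives > 20000 nM, a limit of the assay rather than a number.
- compound 2 `C#Cc1cn([C@@H]2O[C@H](CO)[C@@H](O)[C@H]2O)c2ncnc(OC)c12`; in this assay compound 2 gives 12700 nM.
- compound 3 `COc1ncnc2c1c(-c1ccccc1)cn2[C@@H]1O[C@H](CO)[C@@H](O)[C@H]1O`; in this assay compound 3 gives > 20000 nM, again a limit of the assay and not a number.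

Compound 3 therefore stands at the limit, where it shares its place with one other value in the set: the limit of > 20000 nM in this assay, at which 2 of the 3 values shown sit. The two steps reaching compound 3 give little to work with: a step that the two limits leave unreadable from compound 1 to compound 3, and an at least 1.5-fold higher number from compound 2 to compound 3 (0.19 log units; that floor lies within the scatter).

The next compound is compound 4 `COc1ncnc2c1c(-c1ccco1)cn2[C@@H]1O[C@H](CO)[C@@H](O)[C@H]1O`. Its difference from compound 3 is furan-2-yl in place of phenyl on an aromatic carbon. Within the data shown here, no measured step involves furan-2-yl, so the only guidance is that the phenyl-bearing compound 3 and the iodo-bearing compound 1 both sit at the limit, and only the ethynyl-bearing compound 2 returns a number. One five-membered aromatic ring replacing one six-membered aromatic ring on the same carbon of the core is expected to leave compound 4 near where compound 3 stands, so the expected step is a number no higher from compound 3 to compound 4 (the limit leaves the size open), that is, none beyond the scatter. The estimate for compound 4 in this assay is 20000 nM, with a range from 8000 nM to 50000 nM, and a limit reading is the more likely outcome.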

Compound 4, half-maximal inhibitory concentration: 300 nM
Beside the measured number, compound 4's estimate is 67-fold (1.82 log units) above it, and the stated range ends above it.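

At this aromatic carbon of the shared core, two ring bonds from the ring nitrogen, swapping one aromatic ring for another is not a neutral change in this assay: furan-2-yl in place of phenyl gives an at least 66-fold lower number from compound 3 to compound 4 (1.82 log units; beyond the scatter). Among these compounds, compound 4 also clears the only earlier compound with a number, with a 42-fold lower number from compound 2 to compound 4 (1.63 log units; beyond the scatter), and the iodo compound gives way as well, with an at least 66-fold lower number from compound 1 to compound 4 (1.82 log units; beyond the scatter). With all three steps beyond the scatter, compound 4 is the most potent of the set, so this position can carry a large gain, while compound 1 and compound 3 remain limits of the assay and not numbers: the limit of > 20000 nM in this assay, at which 2 of the 4 values shown sit.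

The compounds shown cannot separate the part played by the ring oxygen from that of the five-membered ring, and thiophen-2-yl and furan-3-yl at the same carbon would bear on that question. Going by these compounds, all four compounds also share the methoxy group on the core, so it stays open whether the furan-2-yl gain would hold with an amine in its place.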